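Chain-end change from compound 3 to compound 4

The source may hold more compounds than are shown below. What is called first, only, known or untested is meant among the compounds shown, and "the series" means these compounds.

Measured in a functional assay on mitochondria (Cricetulus griseus) for inhibition of Monoamine oxidase (Homo sapiens), tested at 9 uM; on this read-out lower numbers stand for a weaker effect and higher numbers for a stronger effect at the one concentration tested:
compound 1 `CCOc1ccc2c(=O)c(-c3ccc(O)cc3)coc2c1`: 100%
compound 2 `O=c1c(-c2ccc(O)cc2)coc2cc(CC3OC(CO)C(O)C(O)C3O)ccc12`: 0%
compound 3 `O=c1c(-c2ccc(O)cc2)coc2cc(OCCCBr)ccc12`: 100%

Compound 3 stands level with compound 1 at the digits shown, the two together the highest of the three; compound 2 lies far lower, beyond the scatter. Going by the values given here, the one step measured along this chain, no change at the digits printed from compound 1 to compound 3 (within the scatter), put bromomethyl in place of hydrogen without moving the read-out. Compound 4 `O=C(O)CCCCCCOc1ccc2c(=O)c(-c3ccc(O)cc3)coc2c1` differs from compound 3 by 3-carboxypropyl in place of bromo on a saturated chain carbon, three bonds along the chain from an oxygen on an aromatic ring. Among the compounds with values here, no measured step exchanges bromo for 3-carboxypropyl, and compound 2, the only compound standing far lower, differs in a way no measured step covers. Going by the one step that bears, the step expected in this assay is a number 10 percentage points lower from compound 3 to compound 4 (within the scatter), nothing beyond the scatter. For compound 4 the estimate is 90%, range 60% to 100%.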

Compound 4, a percentage reported as inhibition, at one concentration (the size of the read-out at that concentration, not a potency): 94.6%
Estimate against measurement, compound 4: 4.6 percentage points below; measured number inside the range.
By their numbers in this assay, from the lowest: compound 2; then compounds 4, 1 and 3 (each within the scatter of the next).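

In this assay, going by these compounds alone, the position takes a much larger chain end than the earlier compounds showed: 3-carboxypropyl in place of bromo gives a number 5.4 percentage points lower from compound 3 to compound 4 (within the scatter), and 4-carboxybutyl in place of hydrogen gives a number 5.4 percentage points lower from compound 1 to compound 4 (within the scatter). A carboxylic acid at the chain end, with a hydrogen-bond donor and acceptor that bromo lacks, thus leaves the read-out within the scatter. No evidence on the reason is available.

On these data alone, whether an amine in place of the carboxylic acid holds the read-out stays open. A read-out at one concentration also tells of compound 1, compound 3 and compound 4 only the size of the effect at that concentration.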